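This account rests on a few compounds, and the source may have more. Where it says the series, first, only, none or still open, it means among the compounds named here.

In an in vitro ADME assay on microsomes from Gut (Homo sapiens) for metabolic stability, using NADPH (a lower number here means slower removal, a higher number faster removal of the compound), compound 1 `COc1ccc(Cl)cc1Cn1c(C(=O)NCC(C)(C)CO)cc2cc(C#N)ccc21` gives < 6 mL.min-1.g-1, which is a limit of the assay and not a number. Compound 2 `COc1ccc(Cl)cc1Cn1c(C(=O)NCC2(CO)CCC2)cc2cc(C#N)ccc21` gives < 6 mL.min-1.g-1, which is also a limit, so it has no exact position on this scale. The data so far amount to the limit of < 6 mL.min-1.g-1 in this assay, at which 2 of the 2 values shown sit. Among the measured compounds shown here, the one measured step is a step that the two limits leave unreadable from compound 1 to compound 2, and it lies on a saturated chain carbon bound to an amide-type nitrogen. Compound 3 `Cc1ccc(F)cc1Cn1c(C(=O)NCC2(CO)CCC2)cc2cc(C#N)ccc21` changes a different place, with 5-fluoro-2-methylphenyl in place of 5-chloro-2-methoxyphenyl on a saturated chain carbon bound to an aromatic nitrogen. For the measured compounds named here, no measured step covers this exchange, so its size and direction have no direct support. The expectation therefore starts from compound 2 at < 6 mL.min-1.g-1, a limit. No change beyond the usual scatter is expected, and the expected step is a step that the limit leaves unreadable from compound 2 to compound 3. For compound 3 the estimate is 5 mL.min-1.g-1, with an expected range from 2 mL.min-1.g-1 to 12 mL.min-1.g-1.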

Compound 3, intrinsic clearance in microsomes: < 6 mL.min-1.g-1
Compound 3: only a limit was reported; the forecaster's own chance of this, stated with the estimate: 65%; the middle value lies beyond the limit too.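

In this assay, among the compounds shown here, compound 3, like compound 2, gives a limit of the assay and not a number, so no step between compound 2 and compound 3 can be read for 5-fluoro-2-methylphenyl in place of 5-chloro-2-methoxyphenyl. The compounds shown leave open whether compound 1, compound 2 and compound 3 differ at all in intrinsic clearance, as every value is a limit: the limit of < 6 mL.min-1.g-1 in this assay, at which 3 of the 3 values shown sit.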